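The source may report more compounds than this note shows. Statements on the series, on what has been measured and on what is new or still open speak of the compounds shown alone.

Working notes on the series

Two members of the series have been measured in an in vitro ADME assay on microsomes from liver (Homo sapiens) for metabolic stability; on this read-out lower numbers stand for slow clearance and higher numbers for fast clearance. Compound 1 `COc1ccc(-c2cc(-c3ccc(S(=O)(=O)N(C)C)cc3)cnc2N)cn1` gives 98.8 mL.min-1.g-1. Compound 2 `COc1ccc(-c2cc(-c3ccc(C(F)(F)F)cc3)cnc2N)cn1` gives 6.1 mL.min-1.g-1. Between them stands a single change at the aromatic carbon that bears the outer substituent, a 16-fold lower number from compound 1 to compound 2 (1.21 log units; beyond the scatter). For the measured compounds named here, compound 2 therefore stands lowest of the two numbers so far, with compound 1 the only neighbour, far above it.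

Compound 3 `COc1ccc(-c2cc(-c3ccc(-n4cncn4)cc3)cnc2N)cn1` has not yet been measured in this assay. It differs from compound 2 in one place: 1H-1,2,4-triazol-1-yl in place of trifluoromethyl on an aromatic carbon. Going by the values given here, no measured step involves the 1H-1,2,4-triazol-1-yl group; the only step known, from compound 1 to compound 2, shows that exchanging the group at this position can move this assay by a large amount, but it pairs trifluoromethyl with dimethylsulfamoyl and not with the triazole. The expectation is therefore wide and leans toward a higher number than compound 2, since compound 2 already sits at the low end of what has been seen. For compound 3 the estimated step is a 2.5-fold higher number from compound 2 to compound 3 (0.39 log units; beyond the scatter). Compound 3 is thus expected to give about 15 mL.min-1.g-1, within a range from 4 mL.min-1.g-1 to 55 mL.min-1.g-1.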

Compound 3, intrinsic clearance in microsomes: 8 mL.min-1.g-1
Compound 3: the middle estimate sits 1.9-fold (0.27 log units) above what was measured, within the range that was stated.
By their numbers in this assay, from the lowest: compounds 2 and 3 (each within the scatter of the next); then compound 1.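

In this assay the exchange of trifluoromethyl for 1H-1,2,4-triazol-1-yl gives a 1.3-fold higher number from compound 2 to compound 3 (0.12 log units; within the scatter) and so leaves the read-out within the scatter, even though a group with a five-membered aromatic ring and hydrogen-bond acceptors enters where a group with neither stood. For the compounds shown here, replacing dimethylsulfamoyl with the same triazole gives a 12-fold lower number from compound 1 to compound 3 (1.09 log units; beyond the scatter) and shows that the low numbers at this position are not tied to trifluoromethyl alone, as the single earlier step could not show. Among the three compounds, the high number therefore belongs to compound 1 alone, and two quite different groups on this aromatic carbon, para to a large group, give numbers that the scatter does not separate.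

The compounds shown leave open whether the high number follows dimethylsulfamoyl specifically or would also appear with a smaller sulfonamide, a primary amide, an amine or a carboxylic acid at this position. They also leave open how far the low numbers would hold with changes elsewhere on the shared core, and nothing at hand gives a reason for the gap between compound 1 and the other two.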